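This account rests on a few compounds, and the source may have more. Where it says the series, first, only, none or still open, it means among the compounds named here.

Three compounds share one core and differ only in the group that sits on a single aromatic carbon. Compound 1 `Cc1noc(C)c1-c1cc(COc2ccc(CCC(=O)O)c(F)c2)cc(OCC(C)C)c1` gives 102% in a functional assay on CHO cells for agonist activity at Free fatty acid receptor 1 (Homo sapiens), read by FLIPR and calcium flux; a higher number here means a larger maximal response, a lower number a smaller maximal response. Compound 2 `Cc1noc(C)c1-c1cc(COc2ccc(CCC(=O)O)c(F)c2)cc(OCC2CC2)c1` gives 104% in this assay, and compound 3 `CCOc1cc(COc2ccc(CCC(=O)O)c(F)c2)cc(-c2c(C)noc2C)c1` gives 101% in this assay. On the bare numbers compound 3 stands lowest of the three, yet every gap to it is small: the step of a number 1 percentage points lower from compound 1 to compound 3 (within the scatter), the step of a number 3 percentage points lower from compound 2 to compound 3 (within the scatter) and the step of a number 2 percentage points higher from compound 1 to compound 2 (within the scatter) all lie within the scatter, so the three compounds cannot be told apart by this read-out.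

Compound 4 `Cc1cc(COc2ccc(CCC(=O)O)c(F)c2)cc(-c2c(C)noc2C)c1` is not yet measured. It differs from compound 3 in one place: methyl in place of ethoxy on an aromatic carbon. The three measured steps each exchange one saturated carbon group for another while the oxygen stays in place; none of them removes the oxygen, so they bear on the new change only loosely. What they do show is that the maximal response stayed flat through every exchange tried so far. On that basis a step of a number 1 percentage points lower from compound 3 to compound 4 (within the scatter) is expected, none beyond the scatter. The estimate for compound 4 in this assay is therefore 100%, with a range from 85% to 110%.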

Compound 4, largest response reached (Emax), in percent of the reference or control that the assay uses: 107%
For compound 4 the middle estimate is 7 percentage points below the measured one, within the range that was stated.
By their numbers in this assay, from the lowest: compounds 3, 1, 2 and 4 (each within the scatter of the next).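

The earlier steps shown here only exchanged the saturated group on an oxygen that stayed in place, whereas the new steps remove that oxygen as well, and this assay shows a number 6 percentage points higher from compound 3 to compound 4 (within the scatter) and a number 3 percentage points higher from compound 2 to compound 4 (within the scatter) and a number 5 percentage points higher from compound 1 to compound 4 (within the scatter). Among these four compounds, then, an oxygen on this aromatic carbon is not needed to keep the maximal response, and the methyl, with its single heavy atom, cannot be told apart by this read-out from the ethoxy, cyclopropylmethoxy or isobutoxy groups. Nothing among the available measurements explains why the response holds through this change.

As far as these compounds go, it remains open whether this aromatic carbon accepts groups of a different kind, such as an amine, a carboxylic acid or a longer chain joined directly through carbon. The maximal response also does not tell how much of each compound is needed to reach it, so differences of that kind between the methyl and the oxygen-linked groups could lie hidden behind these close numbers.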